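A few compounds are considered here, and "the series" means these few. Any claim that something is new, unique, unknown or untested is made for them only; others in the source may bear on it.

Three compounds have numbers in a functional assay on HT-29 cells (Homo sapiens) for antiproliferative activity, read by sulforhodamine B assay, with a stated time of 72 h; on this read-out lower numbers stand for stronger inhibition and higher numbers for weaker inhibition:
compound 1 `NC(=S)N/N=C/c1ccc2ccccc2n1` gives 100000 nM.
compound 2 `Fc1ccccc1NC(=S)N/N=C/c1ccc2ccccc2n1` gives > 100000 nM, which is a limit of the assay and not a number.
compound 3 `S=C(N/N=C/c1ccc2ccccc2n1)Nc1ccc(Cl)cc1` gives 97200 nM.

Compound 3 holds the lowest of the two numbers, but its nearest neighbour is compound 1, and the step of a 1.0-fold lower number from compound 1 to compound 3 (0.01 log units; within the scatter) lies within the scatter, so the two cannot be told apart. Compound 2 sits at the limit of > 100000 nM in this assay, at which 1 of the 3 values shown sits. All three share the same core and differ only in the group carried on an amide-type nitrogen next to the thiocarbonyl carbon.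

Compound 4 `COc1ccccc1NC(=S)N/N=C/c1ccc2ccccc2n1`, not yet measured, differs from compound 3 by 2-methoxyphenyl in place of 4-chlorophenyl on an amide-type nitrogen. Going by the values given here, the steps that bear on this change are those at the same nitrogen: a 1.0-fold lower number from compound 1 to compound 3 (0.01 log units; within the scatter), a number no lower from compound 1 to compound 2 (the limit leaves the size open) and an at least 1.0-fold lower number from compound 2 to compound 3 (0.01 log units; that floor lies within the scatter). None of them moved the number beyond the scatter, whether the nitrogen carried hydrogen, 2-fluorophenyl or 4-chlorophenyl. On that basis the expected step of a 1.0-fold higher number from compound 3 to compound 4 (0.01 log units; within the scatter) is none beyond the scatter, and the number may again come back as a limit. Compound 4 is therefore estimated at 100000 nM, with a range from 40000 nM to 250000 nM.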

Compound 4, half-maximal inhibitory concentration: > 100000 nM
Compound 4 was reported as a limit; the forecaster's own chance of this, stated with the estimate: 45%; the middle value sits exactly at the limit.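

Replacing 4-chlorophenyl with 2-methoxyphenyl on an amide-type nitrogen adds a hydrogen-bond acceptor, but in this assay the number gets no lower: the result is an at least 1.0-fold higher number from compound 3 to compound 4 (0.01 log units; that floor lies within the scatter). Compared with hydrogen on the same nitrogen, the new group gives a number no lower from compound 1 to compound 4 (the limit leaves the size open), so this oxygen-bearing aromatic group also brings no measurable gain. Compound 2 and compound 4 are both limits of the assay, so the step between them cannot be read, and the limit now holds a larger share of the set: the limit of > 100000 nM in this assay, at which 2 of the 4 values shown sit.

The compounds shown leave open whether any group on this nitrogen can move the number beyond the scatter, for instance a morpholine, a carboxylic acid or a longer chain in place of the aromatic rings. They also leave open whether a change to the shared core, which stays the same in all four compounds, would bring a clearer drop than any change on this nitrogen.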